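Fluoro for methylsulfanyl on the aryl ether of compound 3

The source may report more compounds than this note shows. Statements on the series, on what has been measured and on what is new or still open speak of the compounds shown alone.

Compound 3 `CSc1ccc(OC(C)(C)C2OCC(C/C=C\CCC(=O)O)C(c3cccnc3)O2)c([N+](=O)[O-])c1` gives 22 nM in an assay for inhibition of Thromboxane-A synthase (Homo sapiens), using microsomes (on this read-out higher numbers stand for weaker inhibition and lower numbers for stronger inhibition), the lowest of the three numbers in hand. Compound 1 `O=C(O)CC/C=C\CC1COC(c2ccc(C(F)(F)F)cc2)OC1c1cccnc1` gives 44 nM, within the scatter of compound 3, while compound 2 `O=C(O)CC/C=C\CC1COC(c2ccco2)OC1c1cccnc1` gives 164 nM, beyond it. For the measured compounds named here, the only measured step, a 3.7-fold higher number from compound 1 to compound 2 (0.57 log units; beyond the scatter), concerns the group on a saturated ring carbon and not the aryl ether. Compound 4 `CC(C)(Oc1ccc(F)cc1[N+](=O)[O-])C1OCC(C/C=C\CCC(=O)O)C(c2cccnc2)O1` differs from compound 3 by fluoro in place of methylsulfanyl on an aromatic carbon. Going by the values given here, no measured step touches this aromatic carbon, so nothing speaks for a shift beyond the scatter in this assay; a number near that of compound 3 is the plain expectation. The number expected for compound 4 is 25 nM, with a range of 10 nM to 60 nM. This amounts to an expected step of a 1.1-fold higher number from compound 3 to compound 4 (0.06 log units; within the scatter).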

Compound 4, half-maximal inhibitory concentration: 20 nM
The estimate for compound 4 lay 1.3-fold (0.10 log units) above the measured number; measured number inside the range.
By their numbers in this assay, from the lowest: compounds 4, 3 and 1 (each within the scatter of the next, the first and the last beyond it); then compound 2.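

This aromatic carbon, para to a large group and meta to a nitro group, accepts fluoro in place of methylsulfanyl with a 1.1-fold lower number from compound 3 to compound 4 (0.04 log units; within the scatter) in this assay. For the compounds shown here, this is the first measured step on the aryl ether, and it shows that sulfur and one of the two heavy atoms can go from this carbon without a shift beyond the scatter. Nothing measured bears on why the two groups read alike.

From the compounds shown here alone, whether an amine or a carboxylic acid on this carbon would also stay within the scatter remains open. So does the outcome of a nitrile in place of the nitro group.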